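From 3-iodophenyl to 4-iodophenyl

This account rests on a few compounds, and the source may have more. Where it says the series, first, only, none or still open, it means among the compounds named here.

Of the compounds shown here, two have numbers so far in a functional assay on B16 cells (Mus musculus) for cytotoxicity, read by CCK-8 assay, with a stated time of 24 h; a lower number here means a stronger inhibitor, a higher number a weaker inhibitor. Compound 1 `COc1ccccc1Oc1c(N)nc(-c2cccc(Br)c2)nc1OCCO` gives 21900 nM, and compound 2 `COc1ccccc1Oc1c(N)nc(-c2cccc(I)c2)nc1OCCO` gives 20300 nM. These two values lie within the scatter of each other, so compound 2 has no separate rank in this pair, and both sit in the same range.

Compound 3 `COc1ccccc1Oc1c(N)nc(-c2ccc(I)cc2)nc1OCCO` has the same atoms as compound 2, joined differently: 4-iodophenyl in place of 3-iodophenyl on an aromatic carbon. The change is 4-iodophenyl in place of 3-iodophenyl on an aromatic carbon.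

Going by the values given here, the only measured step is a 1.1-fold lower number from compound 1 to compound 2 (0.03 log units; within the scatter), for iodo in place of bromo on an aromatic carbon, and it lies within the scatter. That step exchanges one atom at a single place and does not move a group around the ring. Among the compounds with values here, no measured pair tests such a move, so it bears on the new change only weakly.

With so little evidence, no shift beyond the scatter is expected, though the range is kept wide. The expected size is a 1.0-fold lower number from compound 2 to compound 3 (0.01 log units; within the scatter). For compound 3 the estimate is 20000 nM, with an expected range of 10000 nM to 40000 nM.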

Compound 3, half-maximal inhibitory concentration: 19600 nM
For compound 3 the middle estimate is 1.0-fold (0.01 log units) above the measured one, within the range that was stated.
By their numbers in this assay, from the lowest: compounds 3, 2 and 1 (each within the scatter of the next).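

Moving iodine from 3-iodophenyl to 4-iodophenyl is the first test in this series of where the halogen sits on the phenyl group carried on the aromatic carbon between two ring nitrogen atoms, and in this assay it gives a 1.0-fold lower number from compound 2 to compound 3 (0.02 log units; within the scatter), so the two placements cannot be told apart in this assay. Changing the halogen and its place in a single step gives a 1.1-fold lower number from compound 1 to compound 3 (0.05 log units; within the scatter), which is also within the scatter, so even the two changes taken together leave compound 1 and compound 3 in the same range. No measured evidence bears on the reason for this flat result.

The compounds shown cover only bromo and iodo on the phenyl group, so it remains open whether an amine or a carboxylic acid in place of the halogen would give a step beyond the scatter. As far as these compounds go, it also remains open whether the halogen's place would still make no visible difference with a longer chain in place of the 2-hydroxyethoxy group, or with a different group in place of the 2-methoxyphenoxy group.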